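The source may report more compounds than this note shows. Statements on the series, on what has been measured and on what is new or still open speak of the compounds shown alone.

Of the compounds shown here, three have been measured in a functional assay on HL-60 cells (Homo sapiens) for inhibition, read by CCK-8 assay, with a stated time of 48 h; a lower number here means a stronger inhibitor, a higher number a weaker inhibitor. Compound 1 `O=C(NCCNS(=O)(=O)c1ccc(-c2ccccc2Oc2ccc(O)c(O)c2)s1)Nc1cc(Cl)cc(Cl)c1` gives 10400 nM. Compound 2 `O=[N+]([O-])c1ccc(Oc2ccc(O)c(O)c2)c(-c2ccsc2S(=O)(=O)N2CCN(C(=S)Nc3cc(C(F)(F)F)cc(C(F)(F)F)c3)CC2)c1` gives 8400 nM, and compound 3 `O=S(=O)(NCCNC(=S)Nc1cc(C(F)(F)F)cc(C(F)(F)F)c1)c1ccc(-c2ccccc2OCc2ccccc2)s1` gives 2100 nM. On these numbers compound 2 holds the second highest of the three: its number and that of compound 1 lie within the scatter of each other, while compound 3 sits at a lower number, beyond the scatter. Within the data shown here, no two measured compounds differ in only one place, so no single step has been resolved.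

Compound 4 `O=S(=O)(c1sccc1-c1ccccc1Oc1ccc(O)c(O)c1)N1CCN(C(=S)Nc2cc(C(F)(F)F)cc(C(F)(F)F)c2)CC1` has not been measured. It differs from compound 2 in one place: hydrogen in place of nitro on an aromatic carbon. Among the measured compounds shown here, no measured pair shows what this change does in this assay, and nothing in the data sets its direction. The expected step is therefore a 1.3-fold lower number from compound 2 to compound 4 (0.11 log units; within the scatter), estimated to stay within the scatter or close to it. For compound 4 the expected value in this assay is 6500 nM, with a range from 2500 nM to 20000 nM.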

Compound 4, half-maximal inhibitory concentration: 2200 nM
Compound 4: the middle estimate sits 3.0-fold (0.47 log units) above what was measured; measured number below the stated range.
By their numbers in this assay, from the lowest: compounds 3 and 4 (each within the scatter of the next); then compounds 2 and 1 (each within the scatter of the next).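

Hydrogen in place of nitro on this aromatic carbon, para to the 3,4-dihydroxyphenoxy group, gives the first resolved single-place step in the series: in this assay it brings a 3.8-fold lower number from compound 2 to compound 4 (0.58 log units; beyond the scatter), a step beyond the scatter, though read from one pair only. The position is therefore not silent in this assay, and the nitro group is not required here, since compound 4 reaches 2200 nM with no heavy atom at this carbon. No measurement available here explains the size of this step.

As far as these compounds go, whether an amine, a nitrile or a methoxy group on this carbon would sit nearer compound 2 or compound 4 remains open. Also open, from the compounds shown here alone, is whether the same change gives a step of similar size on a core with the urea or thiourea attached through an ethylene chain rather than the piperazine.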